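Thiophene carboxamide series: pyrrole in place of chlorophenyl

A few compounds are considered here, and "the series" means these few. Any claim that something is new, unique, unknown or untested is made for them only; others in the source may bear on it.

Three compounds share the core, differing only at the amine nitrogen in the ring. Compound 1 `NC(=O)c1c(NC(=O)c2ccccc2Cl)sc2c1CCN(Cc1cc(Cl)cc(Cl)c1)C2` carries a dichlorobenzyl group there and in a functional assay on HL-60 cells (Homo sapiens) for antiproliferative activity, with a stated time of 24 h (on this read-out lower numbers stand for stronger inhibition and higher numbers for weaker inhibition), compound 1 gives 15800 nM. Compound 2 `NC(=O)c1c(NC(=O)c2ccccc2Cl)sc2c1CCN(C(=S)Nc1ccccc1F)C2` gives 4970 nM, and compound 3 `NC(=O)c1c(NC(=O)c2ccccc2Cl)sc2c1CCN(C(=S)Nc1cccnc1)C2` gives 33900 nM. Compound 3 stands highest of the three: the steps run a 2.1-fold higher number from compound 1 to compound 3 (0.33 log units; beyond the scatter) and a 6.8-fold higher number from compound 2 to compound 3 (0.83 log units; beyond the scatter), while a 3.2-fold lower number from compound 1 to compound 2 (0.50 log units; beyond the scatter) went the other way.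

Compound 4 `NC(=O)c1c(NC(=O)c2ccc[nH]2)sc2c1CCN(C(=S)Nc1cccnc1)C2` keeps the thiourea of compound 3 and changes the other end: 1H-pyrrol-2-yl in place of 2-chlorophenyl on a carbonyl carbon. Among the measured compounds shown here, no measured pair varies this carbonyl substituent; every step so far sits on the amine nitrogen in the ring, so nothing reports how this assay responds to a change on the carbonyl carbon. The three measured steps, all modest, set no direction for it.

Without a bearing step, the expectation for compound 4 is a number near that of compound 3, with a wide range: no change at the digits printed from compound 3 to compound 4 (within the scatter) is estimated, and compound 4 is expected to give 33900 nM, between 10000 nM and 100000 nM.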

Compound 4, half-maximal inhibitory concentration: > 50000 nM
Compound 4 gave a limit, no number; the forecaster's own chance of this, stated with the estimate: 25%; middle value at least 1.4-fold (0.16 log units) away from the limit.
By their numbers in this assay, from the lowest: compound 2; then compound 1; then compound 3. At a limit, above all of these: compound 4.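

Compound 4 gives no number in this assay, only a limit of the assay: the limit of > 50000 nM in this assay, at which 1 of the 4 values shown sits. The one change shown on the carbonyl carbon gives an at least 1.4-fold higher number from compound 3 to compound 4 (0.16 log units; that floor lies within the scatter), so the size of this step stays unknown, and its floor does not by itself separate compound 4 from compound 3 beyond the usual scatter. Even so, this is the first reading at this position: with the pyridin-3-yl thiourea held fixed, 1H-pyrrol-2-yl in place of 2-chlorophenyl brings no stronger inhibition, whereas the earlier steps all sat on the amine nitrogen in the ring.

Still open is whether this reading holds with the 2-fluorophenyl thiourea of compound 2, the lowest number in the series at 4970 nM, since the pyrrole is shown with only one group on the amine nitrogen. Also open, from the compounds shown here alone, is how the carbonyl carbon responds to other groups, such as an unsubstituted phenyl or a furan-2-yl, which would show whether the loss of the chlorine or the change of ring goes with this outcome.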